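This account rests on a few compounds, and the source may have more. Where it says the series, first, only, none or still open, it means among the compounds named here.

The series centres on a shared core that carries, on a saturated chain carbon bound to an aromatic carbon and a double-bonded nitrogen, either a furan-2-yl or a thiophen-2-yl group. Compound 1 `c1ccc(C(/N=C2\CCCCCN2)c2ccco2)cc1` bears the furan-2-yl; compound 3 `c1ccc(C(/N=C2\CCCCCN2)c2cccs2)cc1` bears the thiophen-2-yl on the same core. Compound 2 `c1ccc(C(/N=C2\CCCCCCN2)c2ccco2)cc1` also carries the furan-2-yl, but its core differs from that of compound 1, and the difference between the two cores is not broken down here. Compound 4 `c1ccc(C(/N=C2\CCCCCCN2)c2cccs2)cc1` pairs the core of compound 2 with the thiophen-2-yl group.

In a functional assay on the whole organism (plasma, strain Sprague-Dawley) with Rattus norvegicus as the target, with a stated time of 2 h, at a dose of 100 mg/kg by the oral route (on this read-out lower numbers stand for a weaker effect and higher numbers for a stronger effect at the one dose given), compound 1 gives 52% and compound 3 gives 50%. The change thiophen-2-yl in place of furan-2-yl on a saturated chain carbon bound to an aromatic carbon and a double-bonded nitrogen thus made a step of a number 2 percentage points lower from compound 1 to compound 3 (within the scatter). In this assay compound 2 gives 61%.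

The same change, (thiophen-2-yl in place of furan-2-yl on a saturated chain carbon bound to an aromatic carbon and a double-bonded nitrogen), now separates compound 4 from compound 2. Because the step of a number 2 percentage points lower from compound 1 to compound 3 (within the scatter) stayed within the scatter, the step from compound 2 to compound 4 is expected to be small as well, about a number 2 percentage points lower from compound 2 to compound 4 (within the scatter). Resting on the value of compound 2, 61%, compound 4 is estimated at 59%, with a range from 47% to 70% expected to hold most repeat measurements.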

Compound 4, a percentage reported as inhibition, in the whole organism at one dose (the size of the read-out at that dose, not a potency): 41%
Compound 4: the middle estimate sits 18 percentage points above what was measured; measured number below the stated range.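

In this assay, thiophen-2-yl in place of furan-2-yl on a saturated chain carbon bound to an aromatic carbon and a double-bonded nitrogen does not give a step of the same size on the two cores: the same change on two cores in this assay, a number 2 percentage points lower (within the scatter) from compound 1 to compound 3 and a number 20 percentage points lower (beyond the scatter) from compound 2 to compound 4, 18 percentage points apart, beyond the scatter of two such steps. On the core of compound 2 the change therefore has a clear cost, with a number 20 percentage points lower from compound 2 to compound 4 (beyond the scatter), so the near-silent step seen on the core of compound 1 cannot be taken as a guide to what this change does on another core in this series. The result shows that the size of the step depends on the core in these two pairs, but it does not show which feature of the cores is responsible or why, and two pairs read at a single dose and a single time give no general rule.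

The compounds shown hold only furan-2-yl and thiophen-2-yl at this place and only two cores, so it stays open whether the two cores would also part ways with another group there, such as pyridin-2-yl or a simple methyl. As far as these compounds go, it also stays open whether the gap between the two steps would persist at other doses or times in the same animals.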